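Chloro to Bromo on the Aromatic Ring: Compound 3 to Compound 4

The source may hold more compounds than are shown below. What is called first, only, known or untested is meant among the compounds shown, and "the series" means these compounds.

Of the compounds shown here, three built on a shared core have been tested in a functional assay on HBL-100 cells (Homo sapiens) for inhibition, read by sulforhodamine B assay, with a stated time of 48 h; on this read-out lower numbers stand for stronger inhibition of growth and higher numbers for weaker inhibition of growth. Compound 3 `CC(=O)OC/C(=C/c1ccccc1Cl)C(=O)c1ccccc1` gives 21000 nM. Compound 1 `CC(=O)OC/C(=C\c1ccccc1Br)C(=O)c1ccccc1` gives 22000 nM in this assay, a number within the scatter of that of compound 3, so these two cannot be told apart. Compound 2 `CC(=O)OC/C(=C\c1ccc(Cl)cc1Cl)C(=O)c1ccc(Cl)cc1` gives 3200 nM, a number clearly below the other two, beyond the scatter. On the numbers shown, compound 3 therefore stands second highest of the three, close to compound 1 and far from compound 2.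

Compound 4 `CC(=O)OC/C(=C/c1ccccc1Br)C(=O)c1ccccc1` has not yet been measured. It differs from compound 3 in one place: bromo in place of chloro on an aromatic carbon. Within the data shown here, no pair of measured compounds differs only in this way, so the data themselves do not show how large such a swap is. One heavy atom leaves and one enters, and the step that is expected is no change at the digits printed from compound 3 to compound 4 (within the scatter), that is, none beyond the scatter. Compound 4 is therefore estimated at 21000 nM, with a range from 10000 nM to 45000 nM.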

Compound 4, concentration for 50% growth inhibition: 21000 nM
Compound 4: middle estimate and measured number agree at the digits printed; measured number inside the range.
By their numbers in this assay, from the lowest: compound 2; then compounds 3, 4 and 1 (each within the scatter of the next).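

In this assay, the swap at this aromatic carbon can now be read directly, and bromo in place of chloro gives no change at the digits printed from compound 3 to compound 4 (within the scatter). With the bromo group kept in place, the geometry of the double bond can be read as well, and the step is a 1.0-fold lower number from compound 1 to compound 4 (0.02 log units; within the scatter). This second step isolates that single structural difference, with nothing else altered between the two structures: the fact that compounds 1 and 4 differ only in the configuration as drawn

The compounds shown leave open whether a group other than these two halogens at this place, such as an amine, a methoxy group or a carboxylic acid, would shift the number beyond the scatter. Compound 2 differs from the other compounds in more than one place, so its value cannot be tied to any single change.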